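The compounds below may be only part of what the source reports. "The series", "measured", "known", "first", "only" and "open" are said of these compounds alone.

Of the compounds shown here, three have been measured in a functional assay on HT-1080 cells (Homo sapiens) for cytotoxicity, read by MTT assay, with a stated time of 72 h; a higher number here means a weaker inhibitor, a lower number a stronger inhibitor.
Compound 1, `COc1cccc(/C=C2\CCC/C(=C\c3cccc(O)c3)C2=O)c1OC`, gives 8500 nM.
Compound 2, `COc1ccc(/C=C2\CCC/C(=C\c3cccc(OC)c3OC)C2=O)c(OC)c1`, reaches a limit of the assay, > 20000 nM.
Compound 3, `COc1ccc(/C=C2\CCC/C(=C\c3ccc(Br)cc3)C2=O)cc1OC`, gives 4300 nM.

Compound 3 carries the lowest of the two numbers on hand; the nearest, that of compound 1, lies within the usual scatter of repeated measurements, so the two cannot be told apart. Compound 2 contributes a limit rather than a number. Compound 4, `COc1ccc(/C=C2\CCC/C(=C\c3cc(Cl)cc(Cl)c3)C2=O)cc1OC`, has not yet been measured. It differs from compound 3 in one place: 3,5-dichlorophenyl in place of 4-bromophenyl on a double-bonded chain carbon bound to a double-bonded ring carbon. Among the compounds with values here, no pair of measured compounds differs in a single place, so there is no measured step to lean on for the exchange of 4-bromophenyl for 3,5-dichlorophenyl. With nothing to point either way, the step expected in this assay is small, not clearly beyond the scatter in either direction; the expected step of a 1.0-fold higher number from compound 3 to compound 4 (0.02 log units; within the scatter) reflects this. Compound 4 is therefore estimated at 4500 nM, with a range from 1500 nM to 13000 nM.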

Compound 4, half-maximal inhibitory concentration: 3000 nM
For compound 4 the middle estimate is 1.5-fold (0.18 log units) above the measured one, and the stated range covers the measured number.
By their numbers in this assay, from the lowest: compounds 4, 3 and 1 (each within the scatter of the next, the first and the last beyond it). At a limit, above all of these: compound 2.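

Within the data shown here, the first change on hand that sits in a single place, 3,5-dichlorophenyl in place of 4-bromophenyl on a double-bonded chain carbon bound to a double-bonded ring carbon, gives a 1.4-fold lower number from compound 3 to compound 4 (0.16 log units; within the scatter) in this assay. At this place, then, a phenyl ring with two chlorine atoms and one with a single bromine atom cannot be told apart in this measurement, and the two compounds count as equals. Nothing measured here says why the two groups match so closely.

As far as these compounds go, these two halogen-bearing rings show only how far this place tolerates one kind of group, so it remains open whether an amine, a carboxylic acid or a longer chain there would give a step beyond the scatter. From the compounds shown here alone, it is also open whether the same exchange would give a similar step on the core of compound 1.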